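The compounds below may be only part of what the source reports. "The series", "measured", "known", "first", "only" and "open" are said of these compounds alone.

Measured compounds:
Compound 1, `CCOC(=O)/C=C/c1ccncc1-c1ccc2c(cnn2C)c1`, in an assay on a protein complex for inhibition of CDK8/Cyclin C (Homo sapiens), with a stated time of 1 h (on this read-out higher numbers stand for weaker inhibition and lower numbers for stronger inhibition), gives 102 nM.
Compound 2, `Cn1ncc2cc(-c3cnccc3/C=C/C(=O)N3CCOCC3)ccc21`, in this assay gives 356 nM.
Compound 3, `CCOC(=O)/C=C/c1ccncc1-c1ccc2cc[nH]c2c1`, in this assay gives 12.1 nM.

Compound 3 stands at the lowest number of the three, and its gap to compound 1 and to compound 2 lies beyond the usual scatter. For the measured compounds named here, the one change that has been measured directly is morpholin-4-yl in place of ethoxy on a carbonyl carbon, which produced a 3.5-fold higher number from compound 1 to compound 2 (0.54 log units; beyond the scatter). Compound 4, `O=C(/C=C/c1ccncc1-c1ccc2cc[nH]c2c1)N1CCOCC1`, carries the same change made on compound 3: morpholin-4-yl in place of ethoxy on a carbonyl carbon. The place of the change is described in the same words for both pairs. How the core of compound 1 and the core of compound 3 differ is not broken down here.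

Going by the values given here, compound 4 is expected to show a 3.5-fold higher number from compound 3 to compound 4 (0.54 log units; beyond the scatter), a step of the same kind and size as the one seen from compound 1 to compound 2, because a 3.5-fold higher number from compound 1 to compound 2 (0.54 log units; beyond the scatter) is the only guide available. The estimate for compound 4 is 42 nM, within 20 nM to 90 nM.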

Compound 4, half-maximal inhibitory concentration: 43.9 nM
The estimate for compound 4 lay 1.0-fold (0.02 log units) below the measured number; the range from low to high includes it.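

In this assay, morpholin-4-yl in place of ethoxy on a carbonyl carbon gave a 3.6-fold higher number from compound 3 to compound 4 (0.56 log units; beyond the scatter), and this step matches the earlier one: the same change on two cores in this assay, a 3.5-fold higher number (0.54 log units; beyond the scatter) from compound 1 to compound 2 and a 3.6-fold higher number (0.56 log units; beyond the scatter) from compound 3 to compound 4, 1.0-fold (0.02 log units) apart, within the scatter of two such steps. On these two cores, then, the change carried over with its size preserved, and the ethoxy compound holds the lower number in both pairs. Two pairs cannot show that the step would keep this size on any other core, and they do not explain why it has this size.

The compounds shown leave open how other groups on the carbonyl carbon would read, such as an open-chain amine like dimethylamino, piperidin-1-yl or a longer alkoxy chain. Going by these compounds, a free carboxylic acid in place of the ester also remains open.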